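The compounds below may be only part of what the source reports. "The series", "measured", "known", "first", "only" and "open" are said of these compounds alone.

Three compounds share one core and differ in a single group on an aromatic carbon. Compound 1 `CN(C)c1c(C#N)c2c(N)ncnc2n1C` carries a dimethylamino group; in an assay on isolated protein for binding affinity to Leucine-rich repeat serine/threonine-protein kinase 2 (Homo sapiens), read by TR-FRET and LanthaScreen, with a stated time of 2 h (on this read-out lower numbers stand for stronger inhibition and higher numbers for weaker inhibition), compound 1 gives 111 nM. Compound 2 `Cn1c(N2CCCC2)c(C#N)c2c(N)ncnc21` carries a pyrrolidin-1-yl group, and compound 2 gives 41 nM. Compound 3 `Cn1c(-n2cccc2)c(C#N)c2c(N)ncnc21` carries a 1H-pyrrol-1-yl group, and compound 3 gives 239 nM. Compound 3 thus stands with the highest number of the three: a 2.2-fold higher number from compound 1 to compound 3 (0.33 log units; beyond the scatter), and a 5.8-fold higher number from compound 2 to compound 3 (0.77 log units; beyond the scatter). Compound 4 `C[C@H]1CCCN1c1c(C#N)c2c(N)ncnc2n1C` is the next step, and the change is 2-methylpyrrolidin-1-yl in place of 1H-pyrrol-1-yl on an aromatic carbon. The group that enters is a five-membered non-aromatic ring, as in compound 2, but now with a methyl and a defined stereocentre. The measured step that bears most directly on this is a 5.8-fold higher number from compound 2 to compound 3 (0.77 log units; beyond the scatter), where the aromatic ring gave the weaker binding. Going back to a non-aromatic ring should undo much of that rise; no measured pair shows what the added methyl does, so that part stays open. Compound 4 is therefore expected to show a step of a 4.8-fold lower number from compound 3 to compound 4 (0.68 log units; beyond the scatter). Compound 4 is estimated at 50 nM, within a range from 15 nM to 160 nM.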

Compound 4, inhibition constant: 136 nM
For compound 4 the middle estimate is 2.7-fold (0.43 log units) below the measured one; measured number inside the range.
By their numbers in this assay, from the lowest: compound 2; then compounds 1, 4 and 3 (each within the scatter of the next, the first and the last beyond it).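

Within this assay, this is the first measured look at a substituent on the saturated ring, and placing a methyl on a saturated ring carbon weakens binding, with a 3.3-fold higher number from compound 2 to compound 4 (0.52 log units; beyond the scatter). That single methyl removes the clear edge of the pyrrolidin-1-yl group: the 2-methylpyrrolidin-1-yl compound cannot be told apart from the aromatic 1H-pyrrol-1-yl compound, with a 1.8-fold lower number from compound 3 to compound 4 (0.24 log units; within the scatter), or from the open dimethylamino compound, with a 1.2-fold higher number from compound 1 to compound 4 (0.09 log units; within the scatter). Nothing available explains why the methyl has this effect.

The compounds shown leave open how the opposite stereocentre of the 2-methylpyrrolidin-1-yl group would behave. They also leave open whether a methyl elsewhere on the ring, as in a 3-methylpyrrolidin-1-yl group, or a larger piperidin-1-yl ring would keep the binding of compound 2.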